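The source may report more compounds than this note shows. Statements on the series, on what has been measured and on what is new or still open speak of the compounds shown alone.

Measured in a functional assay on the whole organism with Rattus norvegicus as the target; a lower number here means that less compound is needed, a higher number that more compound is needed for the effect:
- compound 1 `CCOC(=O)C(=O)Nc1ccc(N)cc1C#N`: 8.8 mg/kg
- compound 2 `CCOC(=O)C(=O)Nc1cccc(N)c1C#N`: 0.07 mg/kg
- compound 3 `CNc1cccc(NC(=O)C(=O)O)c1C#N`: 0.07 mg/kg

Compound 2 stands level with compound 3, the two sharing the lowest number of the set, while compound 1 lies far higher, beyond the scatter. The next structure is compound 4 `CCCNc1cccc(NC(=O)C(=O)OCC)c1C#N`, which replaces hydrogen with propyl on a nitrogen on an aromatic ring (propyl in place of hydrogen on a nitrogen on an aromatic ring). For the measured compounds named here, no measured pair isolates this change. Compound 3, which also has a carbon group on that nitrogen, still gives 0.07 mg/kg, so no large loss is foreseen. The expected change a 2.1-fold higher number from compound 2 to compound 4 (0.33 log units; beyond the scatter) is a small rise, near the edge of the scatter. Compound 4 is estimated at 0.15 mg/kg, with an expected range of 0.04 mg/kg to 0.7 mg/kg.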

Compound 4, dose for half-maximal effect: 0.7 mg/kg
Beside the measured number, compound 4's estimate is 4.7-fold (0.67 log units) below it, within the range that was stated.
By their numbers in this assay, from the lowest: compounds 2 and 3 (each within the scatter of the next); then compound 4; then compound 1.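

In this assay, for the compounds shown here, the change from amino to propylamino gives a 10-fold higher number from compound 2 to compound 4 (1.00 log units; beyond the scatter) and is the only single-place step so far. This position is therefore sensitive to substitution with propyl, which requires more compound for the effect while leaving a measurable dose. No measurement here accounts for the step. Still open, going by these compounds, is how the number follows chain length on this nitrogen, with ethyl or butyl in place of propyl. Also open, on these data alone, is whether the step persists when a carboxylic acid replaces the ethyl ester.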